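A few compounds are considered here, and "the series" means these few. Any claim that something is new, unique, unknown or untested is made for them only; others in the source may bear on it.

Compound 1 `CC(C)CCCOc1cccc(O)c1C(=O)/C=C/c1ccc(O)cc1` gives 11000 nM in an assay on THP-1 cells for inhibition of nuclear factor NF-kappa-B complex (Homo sapiens), with stated times of 2 h and 16 h; on this read-out lower numbers stand for stronger inhibition and higher numbers for weaker inhibition.
Compound 2 `CC(C)(C)CCOc1cccc(O)c1C(=O)/C=C/c1ccc(O)cc1` gives 3000 nM in this assay.
Compound 3 `CC(C)=CCOc1cccc(O)c1C(=O)/C=C/c1ccc(O)cc1` reaches only (the limit of > 30000 nM in this assay, at which 1 of the 3 values shown sits); compound 3 gives > 30000 nM in this assay, a limit rather than a number.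

On the numbers shown, compound 3 stands weakest: the steps of an at least 2.7-fold higher number from compound 1 to compound 3 (0.43 log units; beyond the scatter) and an at least 10-fold higher number from compound 2 to compound 3 (1.00 log units; beyond the scatter) both run toward weaker inhibition. Compound 4 `O=C(/C=C/c1ccc(O)cc1)c1c(O)cccc1OCCC1CCCCC1` differs from compound 3 by cyclohexylmethyl in place of 2-methylprop-1-en-1-yl on a saturated chain carbon bound to an oxygen on an aromatic ring. Among the measured compounds shown here, no measured step makes this exact change, but the two saturated chains gave numbers where the unsaturated chain gave only a limit, and the step of a 3.7-fold lower number from compound 1 to compound 2 (0.56 log units; beyond the scatter) shows that a bulkier saturated chain can lower the number further. A return to a measurable value is therefore expected in this assay, with the step of an at least 6.0-fold lower number from compound 3 to compound 4 (0.77 log units; beyond the scatter) estimated. Compound 4 is expected at 5000 nM, between 1500 nM and 20000 nM.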

Compound 4, half-maximal inhibitory concentration: > 30000 nM
Compound 4: only a limit was reported; the forecaster's own chance of this, stated with the estimate: 20%; middle value at least 6.0-fold (0.77 log units) from the limit.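

Replacing the open chain end with a ring does not extend the gain seen with compound 2: in this assay, the change gives an at least 10-fold higher number from compound 2 to compound 4 (1.00 log units; beyond the scatter) and an at least 2.7-fold higher number from compound 1 to compound 4 (0.43 log units; beyond the scatter). A saturated chain alone therefore does not ensure a measurable value at this position, as compound 4 goes against compound 1 and compound 2. The step between compound 3 and compound 4 cannot be read, since each value is a limit and not a number: the limit of > 30000 nM in this assay, at which 2 of the 4 values shown sit.

Going by these compounds, whether a smaller ring, such as cyclopentyl, would restore a measurable value remains open. So does the effect of an amine at the chain end.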